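The source may hold more compounds than are shown below. What is called first, only, known or untested is meant among the compounds shown, and "the series" means these compounds.

Of the compounds shown here, three sharing one core have been measured in a functional assay on Ehrlich cells (Mus musculus) for cytotoxicity, read by trypan blue exclusion, with a stated time of 2 h, tested at 10 ug/mL; on this read-out higher numbers stand for a stronger effect at the one concentration tested and lower numbers for a weaker effect. Compound 1 `N#CC1=C(N)N(c2ccc(S(N)(=O)=O)cc2)C2=C(CCCC2)C1c1ccc(O)cc1` gives 20% in this assay. Compound 2 `COc1ccccc1C1C(C#N)=C(N)N(c2ccc(S(N)(=O)=O)cc2)C2=C1CCCC2` gives 30% in this assay, a step of a number 10 percentage points higher from compound 1 to compound 2 (within the scatter). Compound 3 `N#CC1=C(N)N(c2ccc(S(N)(=O)=O)cc2)C2=C(CCCC2)C1c1ccccc1Cl` gives 0% in this assay, the lowest of the three numbers; compound 1 lies nearest to it and compound 2 furthest. The change from compound 1 to compound 3 brought a number 20 percentage points lower from compound 1 to compound 3 (beyond the scatter), and the change from compound 2 to compound 3 brought a number 30 percentage points lower from compound 2 to compound 3 (beyond the scatter).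

Compound 4 `N#CC1=C(N)N(c2ccc(S(N)(=O)=O)cc2)C2=C(CCCC2)C1c1c(O)ccc2ccccc12` is not yet measured. It differs from compound 3 in one place: 2-hydroxynaphthalen-1-yl in place of 2-chlorophenyl on a saturated ring carbon. Both measured steps into compound 3 bear on this: introducing chloro went with a lower number in each case, while compound 1 with its hydroxy and compound 2 with its methoxy gave the higher numbers. Going by the values given here, compound 4 removes the chloro and brings in a hydroxy on a larger two-ring group; no measured compound carries a second aromatic ring there, so that part of the change is unknown. A step back up of roughly the size of a number 20 percentage points lower from compound 1 to compound 3 (beyond the scatter) reversed is expected. Compound 4 is estimated at 25%, with a range from 5% to 50%, which means an expected step of a number 25 percentage points higher from compound 3 to compound 4 (beyond the scatter).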

Compound 4, a percentage reported as activity, at one concentration (the size of the read-out at that concentration, not a potency): 10%
Compound 4: middle estimate off by 15 percentage points, on the high side, within the range that was stated.
By their numbers in this assay, from the lowest: compounds 3, 4, 1 and 2 (each within the scatter of the next, the first and the last beyond it).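

In this assay the swap of 2-chlorophenyl for 2-hydroxynaphthalen-1-yl gives a number 10 percentage points higher from compound 3 to compound 4 (within the scatter) and the comparison with the 4-hydroxyphenyl group gives a number 10 percentage points lower from compound 1 to compound 4 (within the scatter), so compound 4 cannot be told apart from either neighbour, even though those two differ from each other by more than the scatter. The one clear separation is from the 2-methoxyphenyl group, with a number 20 percentage points lower from compound 2 to compound 4 (beyond the scatter), which shows that losing the chloro and gaining a hydroxy on a larger two-ring group does not by itself bring the number up to that of compound 2. No measurement at hand accounts for any of these steps.

Compound 4 changes ring size and adds a hydroxy in a single move, so the share of each stays unresolved, and a plain naphthalen-1-yl group without the hydroxy would be needed to pull them apart. From the compounds shown here alone, how a phenyl carrying an amine or a carboxylic acid would read on this saturated ring carbon also stays open, as does whether any of these single-concentration numbers would hold at other concentrations.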